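The compounds below may be only part of what the source reports. "The series", "measured", "known", "first", "only" and "open" are said of these compounds alone.

Compound 3 `CCOc1ccc(/C=C(/SCc2ccc(C)cc2)C(=O)c2ccc(Cl)cc2)cc1OC` and compound 4 `CCOc1ccc(/C=C(/Sc2ccc(C)cc2)C(=O)c2ccc(Cl)cc2)cc1OC` share one core, while compound 1 `Cc1ccc(CS(=O)(=O)/C(=C/c2ccc(N(C)C)cc2)C(=O)c2ccc(Cl)cc2)cc1` and compound 2 `Cc1ccc(S(=O)(=O)/C(=C/c2ccc(N(C)C)cc2)C(=O)c2ccc(Cl)cc2)cc1` share another; the difference between the two cores is not broken down here. In a functional assay on DU-145 cells (Homo sapiens) for inhibition, read by trypan blue exclusion, with a stated time of 96 h (a lower number here means a stronger inhibitor of growth, a higher number a weaker inhibitor of growth), compound 3 gives 25000 nM, and compound 1 gives 50000 nM. For compound 2 this assay reports only a limit, > 100000 nM. The change from compound 1 to compound 2 is 4-methylphenyl in place of 4-methylbenzyl on a sulfonyl sulfur and it brought an at least 2.0-fold higher number from compound 1 to compound 2 (0.30 log units; that floor lies within the scatter), a floor only because of the limit of > 100000 nM in this assay, at which 1 of the 3 values shown sits. From compound 3 to compound 4 the same kind of change is made, (4-methylphenyl in place of 4-methylbenzyl on a sulfur), here on a sulfur rather than a sulfonyl sulfur. A step of similar size is expected from compound 3 to compound 4, a 2.4-fold higher number from compound 3 to compound 4 (0.38 log units; beyond the scatter), which rests on an at least 2.0-fold higher number from compound 1 to compound 2 (0.30 log units; that floor lies within the scatter). Compound 4 is therefore estimated at 60000 nM, somewhere between 20000 nM and 200000 nM.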

Compound 4, concentration for 50% growth inhibition: 25000 nM
Beside the measured number, compound 4's estimate is 2.4-fold (0.38 log units) above it; the range from low to high includes it.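

In this assay, 4-methylphenyl in place of 4-methylbenzyl on the sulfur brought no change at the digits printed from compound 3 to compound 4 (within the scatter). Set beside the same change on a sulfonyl sulfur, the result cannot settle whether the two cores respond alike: the same change on two cores in this assay, an at least 2.0-fold higher number (0.30 log units; that floor lies within the scatter) from compound 1 to compound 2 and no change at the digits printed (within the scatter) from compound 3 to compound 4; the limit leaves it open whether they differ. Compound 2 gives only a limit, > 100000 nM, so these two pairs show neither that the change carries over from one core to the other nor that it does not.

The compounds shown leave open what a longer chain in place of 4-methylbenzyl, or an amine or a carboxylic acid on its ring, would do in this assay. They also leave open how much the difference between the two cores itself contributes to the numbers.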